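Swapping an amide for an ether on a pyrrolidine core

This account rests on a few compounds, and the source may have more. Where it says the series, first, only, none or still open, it means among the compounds named here.

Within the data shown here, compound 1 `O=C(N[C@@H]1C[C@H](C(=O)NO)N(S(=O)(=O)c2ccc(Cl)c(Cl)c2)C1)c1cccs1` is the only compound here with a number: in an assay on isolated protein for inhibition of matrix metalloproteinase-9 (Homo sapiens), read by fluorescence, with stated times of 5 min and 30 min (a lower number here means a stronger inhibitor, a higher number a weaker inhibitor), compound 1 gives 100 nM. Its counterpart compound 2 `O=C(N[C@H]1C[C@H](C(=O)NO)N(S(=O)(=O)c2ccc(Cl)c(Cl)c2)C1)c1cccs1` is reported in this assay only as "not active" (no number reported), with no number attached; the two structures differ only in the configuration as drawn (the fact that compounds 1 and 2 differ only in the configuration as drawn). Compound 1 therefore stands alone as the sole quantified point.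

Compound 3 `O=C(NO)[C@H]1C[C@@H](OCc2ccccc2)CN1S(=O)(=O)c1ccc(Cl)c(Cl)c1` keeps the shared core of compound 1 and changes one group: benzyloxy in place of ((thiophen-2-yl)carbonyl)amino on a saturated ring carbon. Among the measured compounds shown here, no measured step between two compounds is available to calibrate a change of this kind, so the expectation rests on compound 1 alone. The step from compound 1 to compound 3 is expected to be modest and, if anything, toward weaker inhibition a 2.5-fold higher number from compound 1 to compound 3 (0.40 log units; beyond the scatter). Compound 3 is estimated at 250 nM, most likely between 60 nM and 1000 nM.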

Compound 3, half-maximal inhibitory concentration: 900 nM
Compound 3: the middle estimate sits 3.6-fold (0.56 log units) below what was measured; measured number inside the range.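

In this assay, putting benzyloxy in place of ((thiophen-2-yl)carbonyl)amino on this saturated ring carbon gives a 9.0-fold higher number from compound 1 to compound 3 (0.95 log units; beyond the scatter), so inhibition here depends on more than the heavy-atom count, which is the same for both groups. The swap changes several things at once: the amide link gives way to an ether oxygen, the hydrogen-bond donor is lost, and a five-membered aromatic ring with a hetero atom is replaced by a six-membered aromatic ring of carbon only. None of the information available identifies which of these changes accounts for the step.

The compounds shown leave open whether the link or the ring matters more, a question that benzoylamino, which pairs the amide link with the carbon-only ring, could help separate. Also open, going by these compounds, is how a simple amine on this carbon would compare.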